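The compounds below may be only part of what the source reports. "The series", "measured", "known", "first", "only" and "open" are said of these compounds alone.

Of the compounds shown here, two sharing one core have been tested in a functional assay on A549 cells (Homo sapiens) for antiproliferative activity, read by MTT assay, with a stated time of 72 h; on this read-out higher numbers stand for weaker inhibition and lower numbers for stronger inhibition. Compound 1 `O=C1O/C(=C\Cn2cc(-c3ccc(Br)cc3)nn2)C(OCc2ccccc2)=C1OCc1ccccc1` gives only a limit, > 100000 nM, which marks the edge of this assay rather than a number; this is the limit of > 100000 nM in this assay, at which 1 of the 2 values shown sits. Compound 2 `CCCCCc1ccc(-c2cn(C[C@H](O)[C@H]3OC(=O)C(OCc4ccccc4)=C3OCc3ccccc3)nn2)cc1` gives 6220 nM in this assay, the only true number among the results shown. Compound 3 `O=C1O[C@H]([C@@H](O)Cn2cc(CCCCl)nn2)C(OCc2ccccc2)=C1OCc1ccccc1` has not been measured. It differs from compound 2 by 3-chloropropyl in place of 4-pentylphenyl on an aromatic carbon. Going by the values given here, no pair of measured compounds differing in one place is available, so the size of such a change is not known from these data. Compound 3 is expected to give roughly 40000 nM in this assay, somewhere between 10000 nM and 150000 nM. That estimate means a step of a 6.4-fold higher number from compound 2 to compound 3 (0.81 log units; beyond the scatter) toward weaker inhibition, expected to lie beyond the usual scatter, with a real chance that only a limit is reported.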

Compound 3, half-maximal inhibitory concentration: 29000 nM
For compound 3 the middle estimate is 1.4-fold (0.14 log units) above the measured one; measured number inside the range.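

In this assay, going by these compounds alone, the first measured change on this aromatic carbon of the five-membered aromatic ring with 3 nitrogen gives a 4.7-fold higher number from compound 2 to compound 3 (0.67 log units; beyond the scatter) toward weaker inhibition. Swapping 4-pentylphenyl, with its six-membered aromatic ring and 11 heavy atoms, for the ringless 3-chloropropyl with 4 heavy atoms therefore weakens the result without abolishing it, as compound 3 still gives a true number. The one result that stays a limit and not a number belongs to compound 1: the limit of > 100000 nM in this assay, at which 1 of the 3 values shown sits.

This single swap changes the ring, the size and the chlorine all at once, so the data cannot say which of these matters. A plain phenyl or a pentyl chain in this place would help separate the ring from the chain, and an amine in place of the chlorine would show what the chlorine itself contributes.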